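Replacing a pyrimidine ring with a cyclopropyl carbamate

A few compounds are considered here, and "the series" means these few. Any claim that something is new, unique, unknown or untested is made for them only; others in the source may bear on it.

For the measured compounds named here, compound 1 `Cc1nccc(N2CCc3nc(C4(C(=O)Nc5ccc(F)cc5)CCC4)ccc32)n1` is the stronger of the two compounds measured so far in an assay on HeLa cells for inhibition of Indoleamine 2,3-dioxygenase 1 (Homo sapiens); on this read-out higher numbers stand for weaker inhibition and lower numbers for stronger inhibition: compound 1 gives 21 nM, whereas compound 2 `Cc1nccc(N2CCc3nc(C4(NC(=O)c5ccc(Cl)cc5)CCC4)ccc32)n1` gives 46 nM, a difference of a 2.2-fold higher number from compound 1 to compound 2 (0.34 log units; beyond the scatter). That measured step concerns the amide-bearing side chain on the saturated ring carbon and leaves the rest of the shared core untouched.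

Compound 3 `O=C(OC1CC1)N1CCc2nc(C3(C(=O)Nc4ccc(F)cc4)CCC3)ccc21` changes a different place. Starting from compound 1, (cyclopropyloxycarbonyl in place of 2-methylpyrimidin-4-yl on a nitrogen on an aromatic ring in a ring). Going by the values given here, no measured pair in this set alters that nitrogen, so the one known step offers no direct guide, and an exchange of an aromatic heterocycle for a small carbamate could move the number either way. The expectation is therefore wide: compound 3 is estimated to give 60 nM, within a range of 10 nM to 400 nM, which would mean an expected step of a 2.9-fold higher number from compound 1 to compound 3 (0.46 log units; beyond the scatter).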

Compound 3, half-maximal inhibitory concentration: 2.7 nM
The estimate for compound 3 lay 22-fold (1.35 log units) above the measured number, outside the stated range (below it).
By their numbers in this assay, from the lowest: compound 3; then compound 1; then compound 2.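

The nitrogen that the earlier pair left untouched turns out to be a sensitive position: in this assay there is a 7.8-fold lower number from compound 1 to compound 3 (0.89 log units; beyond the scatter) when cyclopropyloxycarbonyl replaces 2-methylpyrimidin-4-yl. An aromatic ring on this nitrogen is therefore not required for strong inhibition, at least alongside the (4-fluorophenyl)carbamoyl side chain, and the two groups have the same hydrogen-bond donor and acceptor counts, so those counts do not separate them. No measurement available here accounts for the lower number.

The compounds shown do not tell whether the cyclopropyl ring or the carbamate link matters more, a question that an ethyl carbamate or a cyclopropylcarbonyl amide could help to answer. They also leave open whether the same exchange would lower the number for compound 2, with its ((4-chlorophenyl)carbonyl)amino side chain.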